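The source may report more compounds than this note shows. Statements on the series, on what has been measured and on what is new or still open speak of the compounds shown alone.

For the measured compounds named here, compound 2 `O=C(/C=C/c1ccccc1)Nc1nnc(-c2ccc3c(c2)OCCO3)s1` holds the only measured number here: in a functional assay on HepG2 cells (Homo sapiens) for antiproliferative activity, read by MTT assay, with a stated time of 48 h (on this read-out lower numbers stand for an effect already at smaller amounts and higher numbers for an effect only at larger amounts of compound), compound 2 gives 10.3 ug/mL. Compound 1 `Cc1ccccc1C(=O)Nc1nnc(-c2ccc3c(c2)OCCO3)s1` reached only a limit of the assay, > 100 ug/mL in this assay. Going by the values given here, the one measured step, an at least 9.7-fold lower number from compound 1 to compound 2 (0.98 log units; beyond the scatter), is the sole guide. Compound 3 `O=C(Nc1nnc(-c2ccc3c(c2)OCCO3)s1)c1ccncc1` differs from compound 2 by pyridin-4-yl in place of 2-phenylethenyl on a carbonyl carbon. That change places an aromatic ring directly on the carbonyl again, the arrangement compound 1 shows at the limit of > 100 ug/mL in this assay, at which 1 of the 2 values shown sits, so a higher number is expected for compound 3. Compound 3 is estimated at 60 ug/mL, in a range from 15 ug/mL to 150 ug/mL, an expected step of a 5.8-fold higher number from compound 2 to compound 3 (0.77 log units; beyond the scatter).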

Compound 3, half-maximal effective concentration: > 100 ug/mL
Compound 3: a limit, no number; the forecaster's own chance of this, stated with the estimate: 45%; middle value at least 1.6-fold (0.22 log units) from the limit.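

Pyridin-4-yl in place of 2-phenylethenyl gives an at least 9.7-fold higher number from compound 2 to compound 3 (0.98 log units; beyond the scatter), so in this assay the 2-phenylethenyl group at this carbonyl carbon cannot be swapped for this ring without losing the measurable effect. Compound 3 reaches only a limit of the assay, and with compound 1 also a limit, the step between them cannot be read. A six-membered aromatic ring on the carbonyl carbon thus ends at the limit both with and without a ring nitrogen: the limit of > 100 ug/mL in this assay, at which 2 of the 3 values shown sit.

The compounds shown leave open whether the double bond itself matters, which a saturated 2-phenylethyl group could test. They also leave open whether a chain ending in an amine would keep the effect.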